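Removing the bromine from the weakest of three hydroxamic acids

The source may hold more compounds than are shown below. What is called first, only, known or untested is meant among the compounds shown, and "the series" means these compounds.

Three hydroxamic acids were tested in an assay on Sf9 cells for inhibition of protein deacetylase HDAC6 (Homo sapiens), read by fluorescence, with a stated time of 40 min; on this read-out lower numbers stand for stronger inhibition and higher numbers for weaker inhibition. Compound 1 `Cc1ccc(-c2nc(CNc3ccc(C(=O)NO)cc3)n(-c3ccccc3)n2)cc1` gives 224 nM, compound 2 `COc1ccc(-n2nc(-c3ccc(O)cc3)nc2CNc2ccc(C(=O)NO)cc2)cc1` gives 102 nM, and compound 3 `O=C(NO)c1ccc(NCc2nc(-c3ccccc3)nn2-c2ccc(Br)cc2)cc1` gives 1730 nM, the highest number of the three and beyond the scatter from both others. Compound 4 `O=C(NO)c1ccc(NCc2nc(-c3ccccc3)nn2-c2ccccc2)cc1` is compound 3 with hydrogen in place of bromo on an aromatic carbon, para to a large group: hydrogen in place of bromo on an aromatic carbon. Compound 4 carries the same phenyl on the ring nitrogen as compound 1, whose number in this assay is far lower than that of compound 3. Compound 4 is therefore expected to improve beyond the scatter, with the step of a 4.9-fold lower number from compound 3 to compound 4 (0.69 log units; beyond the scatter). The estimate for compound 4 is 350 nM, within 120 nM to 1000 nM.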

Compound 4, half-maximal inhibitory concentration: 112 nM
Compound 4: the middle estimate sits 3.1-fold (0.49 log units) above what was measured, and the stated range ends above it.
By their numbers in this assay, from the lowest: compounds 2, 4 and 1 (each within the scatter of the next, the first and the last beyond it); then compound 3.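

In this assay the change from 4-bromophenyl to phenyl is a large one, a 15-fold lower number from compound 3 to compound 4 (1.19 log units; beyond the scatter), so the high number of compound 3 goes with the bromo at this place and not with the shared core. Hydrogen in place of methyl on an aromatic carbon stays within the scatter, a 2.0-fold lower number from compound 1 to compound 4 (0.30 log units; within the scatter), so that change leaves the number unmoved. Nothing given here explains why bromo at this place costs so much. As far as these compounds go, it remains open whether fluoro, chloro, an amine or a carboxylic acid at this place would behave like bromo or like hydrogen.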